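The source may report more compounds than this note shows. Statements on the series, on what has been measured and on what is new or still open speak of the compounds shown alone.

The series shares one core; compound 1 `CCNc1ccc(NC(=O)c2cc(Cl)ccc2O)c(Cl)c1` carries an ethyl. Within the data shown here, in an ADME assay on A549 cells (Homo sapiens) for cytotoxicity, read by resazurin assay, with a stated time of 48 h (on this read-out higher numbers stand for lower toxicity in this test and lower numbers for higher toxicity in this test), compound 1 gives 30200 nM, the highest of the three numbers measured so far. Compound 2 `O=C(Nc1ccc(NCC2CC2)cc1Cl)c1cc(Cl)ccc1O` gives 14400 nM and compound 3 `O=C(Nc1ccc(NCc2ccccc2)cc1Cl)c1cc(Cl)ccc1O` gives 19700 nM. The step of a 2.1-fold lower number from compound 1 to compound 2 (0.32 log units; beyond the scatter) is beyond the scatter, while the step of a 1.5-fold lower number from compound 1 to compound 3 (0.19 log units; within the scatter) and the step of a 1.4-fold higher number from compound 2 to compound 3 (0.14 log units; within the scatter) fall within it.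

Compound 4 `O=C(Nc1ccc(NCc2cc(F)cc(Cl)c2)cc1Cl)c1cc(Cl)ccc1O` remains to be measured in this assay. Its change from compound 1 is 3-chloro-5-fluorophenyl in place of methyl on a saturated chain carbon bound to a nitrogen on an aromatic ring. The step that bears on it most directly is a 1.5-fold lower number from compound 1 to compound 3 (0.19 log units; within the scatter): compound 3 carries an unsubstituted phenyl at the same place. Among the measured compounds shown here, no step in the set adds a chlorine and a fluorine to such a ring. The larger groups tried here move the number only modestly, so for compound 4 a step of about a 2.0-fold lower number from compound 1 to compound 4 (0.30 log units; within the scatter) is expected, at or near the edge of the scatter. For compound 4 the expected value is 15000 nM, with a range from 6000 nM to 40000 nM.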

Compound 4, half-maximal cytotoxic concentration: 11100 nM
Estimate against measurement, compound 4: 1.4-fold (0.13 log units) above, within the range that was stated.
By their numbers in this assay, from the lowest: compounds 4, 2, 3 and 1 (each within the scatter of the next, the first and the last beyond it).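

In this assay the 3-chloro-5-fluorophenyl at this place gives a 2.7-fold lower number from compound 1 to compound 4 (0.43 log units; beyond the scatter) and so stands apart from the ethyl of compound 1, whereas the unsubstituted phenyl of compound 3 stayed within the scatter of it. Adding the two halogens to that phenyl gives only a 1.8-fold lower number from compound 3 to compound 4 (0.25 log units; within the scatter) and the change from cyclopropyl gives a 1.3-fold lower number from compound 2 to compound 4 (0.11 log units; within the scatter) so compound 4 cannot be told apart from compound 3 or compound 2 on these numbers, and the larger groups at this place form one overlapping band. No measurement here explains these steps.

Whether the step from compound 1 needs both halogens stays open, since a phenyl bearing only a chlorine or only a fluorine is absent from the compounds shown. Also open, as far as these compounds go, is how this read-out responds to an amine or a carboxylic acid on that ring, or to a longer chain at this place.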